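Replacing 3,4-dichlorophenyl with butyl in compound 4

The compounds below may be only part of what the source reports. "The series", "measured", "known", "first", "only" and "open" are said of these compounds alone.

In a functional assay on cells (T-cell line, Homo sapiens) for inhibition (a lower number here means a stronger inhibitor, a higher number a weaker inhibitor), compound 1 (`COc1ccc(CCCN2CCC(COCc3ccccc3)CC2)cc1`) gives 2100 nM and compound 2 (`COc1ccc(CCCN2CCC(COCc3ccccn3)CC2)cc1`) gives 5900 nM on the same scale. Within the data shown here, putting pyridin-2-yl in place of phenyl produced a 2.8-fold higher number from compound 1 to compound 2 (0.45 log units; beyond the scatter) and is the only measured single change here. Compound 3 (`Clc1ccc(CCCN2CCC(COC(c3ccccc3)c3ccccc3)CC2)cc1Cl`) reads 2200 nM and so lies within the scatter of compound 1, with a lower number than compound 2.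

Compound 4 (`CCCCCCCN1CCC(COC(c2ccccc2)c2ccccc2)CC1`) carries butyl in place of 3,4-dichlorophenyl on a saturated chain carbon, three bonds along the chain from an amine nitrogen in a ring. Among the measured compounds shown here, no measured step touches that place. The modest step of a 2.8-fold higher number from compound 1 to compound 2 (0.45 log units; beyond the scatter) is therefore only a loose guide to size, and it hints at little about direction. A small move towards weaker inhibition is expected, though it may not clear the scatter. The estimated step is a 1.4-fold higher number from compound 3 to compound 4 (0.13 log units; within the scatter) in this assay on this reasoning. The estimate for compound 4 is 3000 nM with an expected range from 1000 nM to 9000 nM until a measurement arrives.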

Compound 4, half-maximal inhibitory concentration: 500 nM
Estimate against measurement, compound 4: 6.0-fold (0.78 log units) above; measured number outside the range, below it.
By their numbers in this assay, from the lowest: compound 4; then compounds 1 and 3 (each within the scatter of the next); then compound 2.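

In this assay, among these compounds, the only earlier single change lay elsewhere in the molecule and raised the number, whereas this one, on a saturated chain carbon, three bonds along the chain from an amine nitrogen in a ring, gives a 4.4-fold lower number from compound 3 to compound 4 (0.64 log units; beyond the scatter). So, with the rest of compound 3 unchanged, this place does not need an aromatic ring or chlorine for inhibition: butyl, with no ring and 4 heavy atoms against 8, gives the lower number. Nothing available explains why this swap lowers the number.

The swap removes the ring and both chlorines together, so the compounds shown cannot separate the contribution of each. From the compounds shown here alone, it also stays open whether a longer chain such as octyl, or a cyclohexyl group, would do better or worse than butyl here.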